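Trifluoromethyl for Isopropyl on Two Cores, All at the Limit

This account rests on a few compounds, and the source may have more. Where it says the series, first, only, none or still open, it means among the compounds named here.

In an assay on HEK293 cells for inhibition of transient receptor potential cation channel subfamily V member 1 (Homo sapiens), read by FLIPR (on this read-out lower numbers stand for stronger inhibition and higher numbers for weaker inhibition), compound 1 `CC(C)c1ccc(NC(=O)N2CCN(c3ccc(-c4ccccc4)nn3)CC2)cc1` gives only a limit, > 10000 nM.
In this assay compound 2 `O=C(Nc1ccc(C(F)(F)F)cc1)N1CCN(c2ccc(-c3ccccc3)nn2)CC1` gives only a limit, > 10000 nM.
In this assay compound 3 `CC(C)c1ccc(NC(=O)N2CCN(c3nncc4ccccc34)CC2)cc1` gives only a limit, > 10000 nM.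

The change from compound 1 to compound 2 is trifluoromethyl in place of isopropyl on an aromatic carbon, and the step it made is a step that the two limits leave unreadable from compound 1 to compound 2. All three measured values sit at one limit, (the limit of > 10000 nM in this assay, at which 3 of the 3 values shown sit), so no size can be read from them. How the core of compound 3 differs from the core of compound 1 is not broken down here. Compound 4 `O=C(Nc1ccc(C(F)(F)F)cc1)N1CCN(c2nncc3ccccc23)CC1` carries the same change on the core of compound 3, (trifluoromethyl in place of isopropyl on an aromatic carbon), with the place described in the same words. Compound 4 is expected to stay at the limit, because compound 3 gives > 10000 nM and the measured step is unreadable. The expected step is a step that the limit leaves unreadable from compound 3 to compound 4, and the estimate for compound 4 is 20000 nM.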

Compound 4, half-maximal inhibitory concentration: > 10000 nM
Compound 4: only a limit was reported; the forecaster's own chance of this, stated with the estimate: 85%; the middle value does not contradict the limit.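

Compound 4, like compound 3, gives only a limit, so no size can be read for the change between them: the limit of > 10000 nM in this assay, at which 4 of the 4 values shown sit.

The compounds shown leave open whether trifluoromethyl and isopropyl differ at all on either core in this assay.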